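From Methyl to 1-Phenylethyl on a Ring Amine Nitrogen

The source may hold more compounds than are shown below. What is called first, only, known or untested is meant among the compounds shown, and "the series" means these compounds.

Compound 1 `CCCn1c(=O)[nH]c2nc(-c3ccc(S(=O)(=O)N4CCN(C)CC4)cc3)[nH]c2c1=O` was tested in an assay on CHO cells for displacement of a labelled ligand from adenosine receptor A3 (Homo sapiens), read by scintillation counting, with a stated time of 45 min, in the presence of a further agent that is not named here; on this read-out higher numbers stand for weaker inhibition and lower numbers for stronger inhibition. In this assay compound 1 gives only a limit, > 1000 nM, and no number. Two relatives share its core and differ from it only in the group on the amine nitrogen in the ring. Compound 2 `CCCn1c(=O)[nH]c2nc(-c3ccc(S(=O)(=O)N4CCN(c5ccc(I)cc5)CC4)cc3)[nH]c2c1=O` carries 4-iodophenyl in place of methyl, and in this assay compound 2 also gives only a limit, > 1000 nM. Compound 3 `CCCn1c(=O)[nH]c2nc(-c3ccc(S(=O)(=O)N4CCN(c5ccc(F)cc5)CC4)cc3)[nH]c2c1=O` carries 4-fluorophenyl in place of methyl, and in this assay compound 3 likewise gives only a limit, > 1000 nM. Because (the limit of > 1000 nM in this assay, at which 3 of the 3 values shown sit), none of the steps among these three can be read: a step that the two limits leave unreadable from compound 1 to compound 2, a step that the two limits leave unreadable from compound 1 to compound 3 and a step that the two limits leave unreadable from compound 2 to compound 3.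

Compound 4 `CCCn1c(=O)[nH]c2nc(-c3ccc(S(=O)(=O)N4CCN(C(C)c5ccccc5)CC4)cc3)[nH]c2c1=O` has not yet been measured. It differs from compound 1 in one place: 1-phenylethyl in place of methyl on an amine nitrogen in a ring. The two measured steps that also replace the methyl with a group bearing an aromatic ring both end at the same limit, so their size and direction cannot be read, and they give no reason to expect a number inside the measured range. The expectation is therefore that compound 4 will most likely again give only a limit in this assay. As a number, compound 4 is estimated at 3000 nM, with a range from 800 nM to 20000 nM. The estimated step that the limit leaves unreadable from compound 1 to compound 4 is expected to remain unreadable against the measured values.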

Compound 4, inhibition constant: > 1000 nM
Compound 4: a limit, no number; the forecaster's own chance of this, stated with the estimate: 80%; the middle value lies beyond the limit too.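

In this assay compound 4 gives only a limit, > 1000 nM, and no number. Its steps from compound 1, compound 2 and compound 3 cannot be read, because all four compounds end the same way: the limit of > 1000 nM in this assay, at which 4 of the 4 values shown sit.

The compounds shown leave open how strongly any of the four inhibits, and whether changing the group on the amine nitrogen in the ring alters that at all.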